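Sulfonamide to Benzylic Alcohol in a Prostaglandin D2 Antagonist Series

This account rests on a few compounds, and the source may have more. Where it says the series, first, only, none or still open, it means among the compounds named here.

Compound 1 `COc1ccc(S(=O)(=O)c2ccccc2Cc2c3c(n(CC(=O)O)c2C)CCNC3=O)cc1` gives 3.9 nM in a functional assay on CHO.K1 cells for antagonist activity at prostaglandin D2 receptor 2 (Homo sapiens), read by GTPgammaS binding, with a stated time of 1 h (on this read-out higher numbers stand for weaker inhibition and lower numbers for stronger inhibition), while compound 2 `Cc1c(Cc2ccccc2S(=O)(=O)N2CCOCC2)c2c(n1CC(=O)O)CCNC2=O` gives 22 nM; the step of a 5.6-fold higher number from compound 1 to compound 2 (0.75 log units; beyond the scatter) places compound 2 at the highest of the two numbers. Compound 3 `Cc1c(Cc2ccccc2C(O)c2ccccc2)c2c(n1CC(=O)O)CCNC2=O` differs from compound 2 by hydroxy(phenyl)methyl in place of (morpholin-4-yl)sulfonyl on an aromatic carbon. No measured step covers this change directly; the only one shown, a 5.6-fold higher number from compound 1 to compound 2 (0.75 log units; beyond the scatter), indicates that a 4-methoxyphenyl on that side gave the lower number than morpholin-4-yl, so a phenyl returning without the sulfonyl may pull the number back down. Compound 3 is therefore expected to show a 2.8-fold lower number from compound 2 to compound 3 (0.44 log units; beyond the scatter), an estimated 8 nM with a range of 2 nM to 40 nM.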

Compound 3, half-maximal inhibitory concentration: 32 nM
Estimate against measurement, compound 3: 4.0-fold (0.60 log units) below; measured number inside the range.
By their numbers in this assay, from the lowest: compound 1; then compounds 2 and 3 (each within the scatter of the next).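

In this assay, hydroxy(phenyl)methyl on this aromatic carbon stands level with (morpholin-4-yl)sulfonyl (a 1.5-fold higher number from compound 2 to compound 3 (0.16 log units; within the scatter)), so this position tolerates a group with no sulfonyl. Restoring a phenyl ring does not by itself match (4-methoxyphenyl)sulfonyl (an 8.2-fold higher number from compound 1 to compound 3 (0.91 log units; beyond the scatter)). Nothing available accounts for either step.

The compounds shown leave open what the hydroxy group contributes, which a ketone or a plain methylene carrying the same phenyl would test. They also leave open whether a 4-methoxyphenyl on the alcohol carbon would approach compound 1.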